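Nitrooxy ester variations on a shared sulfonamide core

The compounds below may be only part of what the source reports. "The series", "measured", "known", "first", "only" and "open" are said of these compounds alone.

Measured in an assay on isolated protein for inhibition of Rho-associated protein kinase 2 (Homo sapiens), read by HTRF, with a stated time of 1 h; on this read-out lower numbers stand for stronger inhibition and higher numbers for weaker inhibition:
compound 1 `C[C@H]1CN(C(=O)OCCCO[N+](=O)[O-])CCCN1S(=O)(=O)c1cccc2cncc(F)c12` gives 25.1 nM
compound 2 `C[C@H]1CN(C(=O)OCCCCCO[N+](=O)[O-])CCCN1S(=O)(=O)c1cccc2cncc(F)c12` gives 25.2 nM
compound 3 `C[C@H]1CN(C(=O)OCCO[N+](=O)[O-])CCCN1S(=O)(=O)c1cccc2cncc(F)c12` gives 58.4 nM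

Compound 3 stands highest of the three measured numbers. The relevant steps are a 2.3-fold higher number from compound 1 to compound 3 (0.37 log units; beyond the scatter) and a 2.3-fold higher number from compound 2 to compound 3 (0.37 log units; beyond the scatter), whereas a 1.0-fold higher number from compound 1 to compound 2 (0.00 log units; within the scatter).

Compound 4 `C[C@H]1CN(C(=O)O[C@@H]2CO[C@H]3[C@@H]2OC[C@@H]3O[N+](=O)[O-])CCCN1S(=O)(=O)c1cccc2cncc(F)c12` is unmeasured. The change is a group of 12 heavy atoms (6 carbon, 1 nitrogen, 5 oxygen; 2 five-membered non-aromatic rings with 1 hetero atom each) in place of a group of 6 heavy atoms (2 carbon, 1 nitrogen, 3 oxygen; no ring), on an oxygen next to a carbonyl group. Within the data shown here, the steps bearing on it are those that lengthen the chain carrying the nitrooxy group, both modest and both lowering the number; no measured step introduces a ring, so the size of the effect of the bicyclic group is unknown. A modest lowering, or no change beyond the scatter, is therefore expected in this assay, with a 1.9-fold lower number from compound 3 to compound 4 (0.29 log units; within the scatter). The expected value for compound 4 is 30 nM, within 12 nM to 75 nM.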

Compound 4, half-maximal inhibitory concentration: 19.5 nM
Beside the measured number, compound 4's estimate is 1.5-fold (0.19 log units) above it, within the range that was stated.
By their numbers in this assay, from the lowest: compounds 4, 1 and 2 (each within the scatter of the next); then compound 3.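

In this assay, the oxygen next to a carbonyl group carries a group with 2 five-membered non-aromatic rings without loss, with a 3.0-fold lower number from compound 3 to compound 4 (0.48 log units; beyond the scatter) as the ring-bearing group replaces 2-(nitrooxy)ethyl. Among these compounds, the shorter chain is therefore not the only group that can be replaced with gain, yet a 1.3-fold lower number from compound 2 to compound 4 (0.11 log units; within the scatter) and a 1.3-fold lower number from compound 1 to compound 4 (0.11 log units; within the scatter) leave compound 4 level with both longer chains. No evidence on the origin of these steps is available.

The compounds shown leave open whether the nitrooxy group is needed, since a hydroxyl or a plain methyl in its place would test this. Going by these compounds, the role of the 4 defined stereocentres also remains open.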